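Aryl variation on the carbonyl carbon of the shared core

The source may hold more compounds than are shown below. What is called first, only, known or untested is meant among the compounds shown, and "the series" means these compounds.

Measured compounds:
compound 1, `COc1ccc(C2CC(=NOC(=O)c3ccc(F)cc3)CC(c3ccc(OC)cc3)N2C)cc1`: 152000 nM
compound 2, `COc1ccc(C2CC(=NOC(=O)c3ccc(Br)cc3)CC(c3ccc(OC)cc3)N2C)cc1`: 121000 nM
compound 3, `COc1ccc(C2CC(=NOC(=O)c3cc([N+](=O)[O-])cc([N+](=O)[O-])c3)CC(c3ccc(OC)cc3)N2C)cc1`: 312000 nM

In a functional assay, with a stated time of 30 min (on this read-out lower numbers stand for stronger inhibition and higher numbers for weaker inhibition), compound 3 stands at the highest of the three numbers. The two steps onto it are a 2.1-fold higher number from compound 1 to compound 3 (0.31 log units; beyond the scatter) and a 2.6-fold higher number from compound 2 to compound 3 (0.41 log units; beyond the scatter), both beyond the scatter, whereas a 1.3-fold lower number from compound 1 to compound 2 (0.10 log units; within the scatter).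

Compound 4, `COc1ccc(C2CC(=NOC(=O)c3cc(O)cc(O)c3)CC(c3ccc(OC)cc3)N2C)cc1`, differs from compound 3 in one place: 3,5-dihydroxyphenyl in place of 3,5-dinitrophenyl on a carbonyl carbon. Only the two steps that introduced the 3,5-dinitrophenyl bear on this position in this assay, and both gave a modestly higher number. Within the data shown here, no measured compound carries a 3,5-dihydroxyphenyl on the carbonyl carbon, so the direction of the new change is not fixed by the data. The nearest guide is that the aryl group on the carbonyl carbon moved the number only modestly in both measured cases, so the expected step for compound 4 in this assay is a 1.7-fold lower number from compound 3 to compound 4 (0.24 log units; within the scatter), a modestly lower number or none beyond the scatter.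

Compound 4 is therefore estimated at 180000 nM in this assay, with a range from 70000 nM to 450000 nM.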

Compound 4, half-maximal inhibitory concentration: 19000 nM
Beside the measured number, compound 4's estimate is 9.5-fold (0.98 log units) above it, outside the stated range (below it).
By their numbers in this assay, from the lowest: compound 4; then compounds 2 and 1 (each within the scatter of the next); then compound 3.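

In this assay, among these compounds, the aryl group on the carbonyl carbon can shift the number much further than the earlier compounds indicated: 3,5-dihydroxyphenyl in place of 3,5-dinitrophenyl gives the only large step in the set (a 16-fold lower number from compound 3 to compound 4 (1.22 log units; beyond the scatter)). This step does not rest on the weakest comparator alone, since the number also falls against both halogenated aryl groups (a 6.4-fold lower number from compound 2 to compound 4 (0.80 log units; beyond the scatter); an 8.0-fold lower number from compound 1 to compound 4 (0.90 log units; beyond the scatter)), so compound 4 now sits lowest, with its steps to all three others beyond the scatter, while the change from fluoro to bromo remains within it. Nothing available explains why 3,5-dihydroxyphenyl behaves so differently from the other aryl groups.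

The compounds shown leave open whether both hydroxyl groups are needed and whether the free hydroxyl matters at all, which 3-hydroxyphenyl and 3,5-dimethoxyphenyl on the same carbonyl carbon would help to separate. They also leave open whether other groups in the same places, such as the amino groups of 3,5-diaminophenyl, would match compound 4 in this assay or lower the number further.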